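The source may hold more compounds than are shown below. What is called first, only, known or untested is meant among the compounds shown, and "the series" means these compounds.

Compound 1 `CCC(COc1cccc(F)c1)OC(=O)NCc1ccccc1` carries a 3-fluorophenyl on an oxygen on a saturated carbon. In an assay for inhibition of zeta-carotene desaturase, chloroplastic/chromoplastic (Capsicum annuum), using a Dixon plot, with a stated time of 8 h (on this read-out lower numbers stand for stronger inhibition and higher numbers for weaker inhibition), compound 1 gives only a limit, > 100000 nM. Compound 2 `CCC(COc1cccc(Cl)c1Cl)OC(=O)NCc1ccccc1` has 2,3-dichlorophenyl in place of 3-fluorophenyl on an oxygen on a saturated carbon. In this assay compound 2 likewise gives only a limit, > 100000 nM. The step that the two limits leave unreadable from compound 1 to compound 2 is thus unreadable, since (the limit of > 100000 nM in this assay, at which 2 of the 2 values shown sit). Compound 2 therefore stands at the limit of this assay, with no number of its own on which to build.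

Compound 3 `CCC(COc1cc(Cl)ccc1Cl)OC(=O)NCc1ccccc1` differs from compound 2 by 2,5-dichlorophenyl in place of 2,3-dichlorophenyl on an oxygen on a saturated carbon. Within the data shown here, the only measured step, a step that the two limits leave unreadable from compound 1 to compound 2, bears on it in so far as it also exchanges one halogenated phenyl for another on the same oxygen, but its size is not readable; both aryl variants tried so far sit at the same place, (the limit of > 100000 nM in this assay, at which 2 of the 2 values shown sit). Compound 3 is therefore expected to sit near the limit as well, with the step that the limit leaves unreadable from compound 2 to compound 3 expected to be none beyond the scatter. The estimate for compound 3 is 150000 nM, with a range from 50000 nM to 500000 nM, and a high chance that this assay again reports only a limit.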

Compound 3, half-maximal inhibitory concentration: > 100000 nM
Compound 3 ended at the assay's limit (the forecaster's own chance of this, stated with the estimate: 85%); the middle value is on the limit's open side.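

In this assay compound 3 gives > 100000 nM, again only a limit. No step among compound 1, compound 2 and compound 3 can therefore be read: the limit of > 100000 nM in this assay, at which 3 of the 3 values shown sit.

The compounds shown leave open whether these three aryl groups differ at all in this assay, and whether any group on this oxygen gives a readable value.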